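Sulfur-to-oxygen ring swap on the amine side chain

A few compounds are considered here, and "the series" means these few. Any claim that something is new, unique, unknown or untested is made for them only; others in the source may bear on it.

Compound 1, `c1ccc2c(c1)CN[C@@H](CN(CCCCNCC1CCSCC1)[C@H]1CCCc3cccnc31)C2`: 69.6 nM
Compound 2, `CC1(C)CCC(NCCCCN(C[C@H]2Cc3ccccc3CN2)[C@H]2CCCc3cccnc32)CC1`: 77.6 nM

In a functional assay on cells for antagonist activity at C-X-C chemokine receptor type 4 (Homo sapiens), read by fluorescence and calcium flux, with stated times of 25 min and 90 s (on this read-out lower numbers stand for stronger inhibition and higher numbers for weaker inhibition), compound 1 gives 69.6 nM and compound 2 gives 77.6 nM; the step of a 1.1-fold higher number from compound 1 to compound 2 (0.05 log units; within the scatter) lies within the scatter, so the two stand together. Compound 3 `C(=C/CN(C[C@H]1Cc2ccccc2CN1)[C@H]1CCCc2cccnc21)\CNCC1CCOCC1` differs from compound 1 by a group of 11 heavy atoms (9 carbon, 1 nitrogen, 1 oxygen; one six-membered non-aromatic ring with 1 hetero atom) in place of a group of 11 heavy atoms (9 carbon, 1 nitrogen, 1 sulfur; one six-membered non-aromatic ring with 1 hetero atom), on a saturated chain carbon bound to an amine nitrogen. Among the measured compounds shown here, the one measured step that bears on this arm, a 1.1-fold higher number from compound 1 to compound 2 (0.05 log units; within the scatter), left the read-out essentially unchanged, so for compound 3 a step of no more than the scatter is expected, with no clear direction. Compound 3 is therefore estimated at 80 nM, within 30 nM to 220 nM, meaning a 1.1-fold higher number from compound 1 to compound 3 (0.06 log units; within the scatter).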

Compound 3, half-maximal inhibitory concentration: 24.2 nM
Compound 3: the middle estimate sits 3.3-fold (0.52 log units) above what was measured; measured number below the stated range.
By their numbers in this assay, from the lowest: compound 3; then compounds 1 and 2 (each within the scatter of the next).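

Where the earlier change of amine side chain left this assay essentially flat, this position proved responsive, with a 2.9-fold lower number from compound 1 to compound 3 (0.46 log units; beyond the scatter). The incoming group carries the oxygen ring in place of the sulfur ring and also brings a double bond outside aromatic rings, so the step belongs to the two features together. No measurement at hand accounts for the shift. As far as these compounds go, it remains open how the oxygen ring would read on a fully saturated chain, or the sulfur ring on the chain with the double bond. A nitrogen in that ring in place of the oxygen is also untested among these compounds.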